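From 4-methoxyphenyl to 4-nitrophenyl in one ester

The source may report more compounds than this note shows. Statements on the series, on what has been measured and on what is new or still open speak of the compounds shown alone.

In a functional assay on PC-3 cells (Homo sapiens) for cytotoxicity, read by MTT assay, with a stated time of 72 h (on this read-out higher numbers stand for weaker inhibition and lower numbers for stronger inhibition), compound 1 (`COc1ccc(/C=C/C(=O)OC/C=C/c2ccc(OC)c(OC)c2)cc1`) gives 181000 nM and compound 2 (`O=C(CCc1ccc(O)c(O)c1)OCCCc1ccccc1`) gives 189000 nM on the same read-out. Within the data shown here, these are the only two numbers at hand, and they lie within the scatter of each other, so compound 1 stands level with compound 2 and neither can be ranked.

Compound 3 (`COc1ccc(/C=C/COC(=O)/C=C/c2ccc([N+](=O)[O-])cc2)cc1OC`) has not yet been measured. It departs from compound 1 at a single place (nitro in place of methoxy on an aromatic carbon) with nitro in place of methoxy on an aromatic carbon, para to a large group. Among the measured compounds shown here, no measured pair differs at one place only, so the data do not show what such a change does in this assay by itself.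

For the measured compounds named here, the only guide is that compound 2, a quite different structure, still gives 189000 nM in the same test. No step beyond the scatter is therefore expected, and the estimated step of a 1.3-fold lower number from compound 1 to compound 3 (0.11 log units; within the scatter) is a small one. Compound 3 is expected at 140000 nM with 50000 nM to 300000 nM as its estimated range.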

Compound 3, half-maximal inhibitory concentration: 212000 nM
Compound 3: middle estimate off by 1.5-fold (0.18 log units), on the low side; the range from low to high includes it.
By their numbers in this assay, from the lowest: compounds 1, 2 and 3 (each within the scatter of the next).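

Among these compounds, putting nitro where methoxy stood, on an aromatic carbon para to a large group, gives the first comparison here in which two compounds differ at one place only, and in this assay it reads a 1.2-fold higher number from compound 1 to compound 3 (0.07 log units; within the scatter). At this position, 4-methoxyphenyl and 4-nitrophenyl therefore cannot be told apart on this read-out, although the entering group brings one more heavy atom and one more hydrogen-bond acceptor than the group it replaces. Nothing at hand explains this result or shows whether it would hold in another test.

From the compounds shown here alone, what remains open is whether this position responds to any group at all: an amine, a carboxylic acid or a longer chain on the same aromatic carbon could still separate from compound 1 in this assay, and only such a result would show whether the place matters. The compounds shown also leave the rest of the ester unexplored one place at a time, including the methoxy groups on the other aromatic ring and the chain that links the two aromatic rings.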